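Working notes: 3-carboxyphenyl to 4-carboxyphenyl

The source may report more compounds than this note shows. Statements on the series, on what has been measured and on what is new or still open speak of the compounds shown alone.

Values in a functional assay (aorta) with Rattus norvegicus as the target (on this read-out higher numbers stand for weaker inhibition and lower numbers for stronger inhibition), so far
Compound 1 `CC1(C)Oc2ccc(C#N)cc2[C@@H](/N=C(\NC#N)Nc2ccc(Cl)cc2)[C@@H]1O` gives 1800 nM
Compound 2 `CC(=O)c1cccc(N/C(=N/[C@@H]2c3cc(C#N)ccc3OC(C)(C)[C@H]2O)NC#N)c1` gives 8400 nM
Compound 3 `CC1(C)Oc2ccc(C#N)cc2[C@@H](/N=C(\NC#N)Nc2cccc(C(=O)O)c2)[C@@H]1O` gives > 100000 nM as a limit of the assay

Compound 3 stands at the limit of > 100000 nM in this assay, at which 1 of the 3 values shown sits, and this is a limit, not a number. The change to compound 4 `CC1(C)Oc2ccc(C#N)cc2[C@@H](/N=C(\NC#N)Nc2ccc(C(=O)O)cc2)[C@@H]1O` is 4-carboxyphenyl in place of 3-carboxyphenyl on an amine nitrogen and reads in words as 4-carboxyphenyl in place of 3-carboxyphenyl on an amine nitrogen. Two large steps bear on it: an at least 55-fold higher number from compound 1 to compound 3 (1.74 log units; beyond the scatter) and an at least 11-fold higher number from compound 2 to compound 3 (1.07 log units; beyond the scatter) and each ends at the 3-carboxyphenyl compound. The step of a 4.7-fold higher number from compound 1 to compound 2 (0.67 log units; beyond the scatter) is modest by comparison. Among the measured compounds shown here, no measured step moves a carboxy group from one place to the other. A carboxyphenyl group stays in compound 4, and given an at least 55-fold higher number from compound 1 to compound 3 (1.74 log units; beyond the scatter) the number in this assay is expected to stay high, with no step beyond the scatter expected. The expected step is an at least 1.2-fold lower number from compound 3 to compound 4 (0.09 log units; that floor lies within the scatter) and it remains an estimate. Compound 4 is estimated at 80000 nM with an expected range from 20000 nM to 200000 nM and a report at the limit is likely.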

Compound 4, half-maximal inhibitory concentration: > 100000 nM
Compound 4 ended at the assay's limit; the forecaster's own chance of this, stated with the estimate: 55%; middle value at least 1.2-fold (0.09 log units) away from the limit.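

In this assay compound 4 gives > 100000 nM, which is a limit of the assay and not a number. The loss is therefore not tied to 3-carboxyphenyl alone: 4-carboxyphenyl also gives no measurable value, with an at least 55-fold higher number from compound 1 to compound 4 (1.74 log units; beyond the scatter) and an at least 11-fold higher number from compound 2 to compound 4 (1.07 log units; beyond the scatter). The step between the two carboxyphenyl compounds cannot be read, so this change on the amine nitrogen has no measured size in this assay: the limit of > 100000 nM in this assay, at which 2 of the 4 values shown sit.

On these data alone, whether the two carboxyphenyl placements differ at all remains open. Also open, as far as these compounds go, is whether a methyl ester or a primary amide in place of the carboxy group would return a measurable value, as the chloro of compound 1 and the acetyl of compound 2 do.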